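Aryl for isopropyl on the ring amine nitrogen

The compounds below may be only part of what the source reports. "The series", "measured", "known", "first", "only" and "open" are said of these compounds alone.

Compound 1 `CC(C)N1CCN(Cc2csc(N)c2C(=O)c2ccc(Cl)cc2)CC1` is the reference point of the series. In an assay on CHO cells for displacement of a labelled ligand from adenosine receptor A3 (Homo sapiens), read by scintillation counting, with a stated time of 120 min, tested at 10 uM (a higher number here means more inhibition at the concentration tested (going by the name of the read-out), a lower number less inhibition), compound 1 gives 0%. Compound 2 `Nc1scc(CN2CCN(c3ccc(Cl)cc3F)CC2)c1C(=O)c1ccc(Cl)cc1` gives 1% in this assay, and compound 3 `Nc1scc(CN2CCN(c3cccc4ccccc34)CC2)c1C(=O)c1ccc(Cl)cc1` gives 0%. Compound 1 stands level with compound 3 at the digits shown, the two together being the lowest of the three numbers, and its furthest neighbour is compound 2, separated only by a number 1 percentage points higher from compound 1 to compound 2 (within the scatter), which is within the scatter.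

Compound 4 `Nc1scc(CN2CCN(c3c(F)cccc3F)CC2)c1C(=O)c1ccc(Cl)cc1` has not been measured in this assay. It differs from compound 1 by 2,6-difluorophenyl in place of isopropyl on an amine nitrogen in a ring. Among the compounds with values here, the steps that bear on it are a number 1 percentage points higher from compound 1 to compound 2 (within the scatter) and no change at the digits printed from compound 1 to compound 3 (within the scatter), each an aryl group entering at the same ring nitrogen, and a number 1 percentage points lower from compound 2 to compound 3 (within the scatter), all within the scatter. Nothing here moves beyond the scatter, so no step beyond the scatter is expected for compound 4 in this assay. The estimate for compound 4 is 1%, with a range of 0% to 10%. The expected step is a number 1 percentage points higher from compound 1 to compound 4 (within the scatter).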

Compound 4, a percentage reported as inhibition, at one concentration (the size of the read-out at that concentration, not a potency): 4%
Beside the measured number, compound 4's estimate is 3 percentage points below it; measured number inside the range.
By their numbers in this assay, from the lowest: compounds 1, 3, 2 and 4 (each within the scatter of the next).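

The 2,6-difluorophenyl group on the ring amine nitrogen gives a number 4 percentage points higher from compound 1 to compound 4 (within the scatter) in this assay, so an aryl group with two fluorines does not separate from isopropyl at this position. It also stays with the two earlier aryl groups, with a number 4 percentage points higher from compound 3 to compound 4 (within the scatter) and a number 3 percentage points higher from compound 2 to compound 4 (within the scatter), so isopropyl, naphthalen-1-yl, 4-chloro-2-fluorophenyl and 2,6-difluorophenyl cannot be ranked here. No measurement available explains why these four groups read alike.

Still open, from the compounds shown here alone, is whether any group on this nitrogen can lift the number beyond the scatter, for example a benzyl group, an acyl group or a chain ending in a carboxylic acid. Also open, going by these compounds, is whether a change elsewhere on the shared core, such as replacing the chlorine on the aryl ketone with a methoxy group, would do so.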